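A few compounds are considered here, and "the series" means these few. Any claim that something is new, unique, unknown or untested is made for them only; others in the source may bear on it.

Measured compounds in a functional assay on CCRF-CEM cells (Homo sapiens) for cytotoxicity, read by MTT assay, with a stated time of 72 h; on this read-out lower numbers stand for stronger inhibition of growth and higher numbers for weaker inhibition of growth:
- compound 1, `CCCCOC(=O)Nc1ccc([Se]C#N)cc1`: compound 1 gives 27900 nM
- compound 2, `CCCCCCOC(=O)Nc1ccc([Se]C#N)cc1`: compound 2 gives 46200 nM

For the measured compounds named here, on these two numbers compound 2 stands at the higher end; its nearest neighbour is compound 1, and the only step in the set, a 1.7-fold higher number from compound 1 to compound 2 (0.22 log units; within the scatter), lies within the scatter, so no order between compound 1 and compound 2 can be read from the data.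

Compound 3, `N#C[Se]c1ccc(NC(=O)OCc2ccccc2)cc1`, is to be measured in this assay. Relative to compound 2 the change is phenyl in place of pentyl on a saturated chain carbon bound to an oxygen next to a carbonyl group. Going by the values given here, the one measured step, a 1.7-fold higher number from compound 1 to compound 2 (0.22 log units; within the scatter), concerns only the length of the saturated chain in that position and did not move the number beyond the scatter. Among the compounds with values here, no measured step exchanges a chain for a phenyl at this position, so the step from compound 2 to compound 3 is only loosely informed by what has been measured.

For compound 3 no step beyond the scatter is expected, with the estimated move given by a 1.2-fold lower number from compound 2 to compound 3 (0.08 log units; within the scatter). Compound 3 is therefore estimated at 38000 nM, within a range of 15000 nM to 95000 nM.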

Compound 3, concentration for total growth inhibition: 48400 nM
Beside the measured number, compound 3's estimate is 1.3-fold (0.11 log units) below it, and the stated range covers the measured number.
By their numbers in this assay, from the lowest: compounds 1, 2 and 3 (each within the scatter of the next).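

In this assay, phenyl in place of pentyl on a saturated chain carbon bound to an oxygen gives a 1.0-fold higher number from compound 2 to compound 3 (0.02 log units; within the scatter), and phenyl in place of propyl at the same carbon gives a 1.7-fold higher number from compound 1 to compound 3 (0.24 log units; within the scatter). The earlier compounds shown here covered only saturated chains at this position, whereas these steps show that a six-membered aromatic ring of carbon only can stand there without a step beyond the scatter, so the set does not separate a ring from a chain at this carbon. No available evidence bears on why the number holds across this exchange.

Open, from the compounds shown here alone, is whether any group at this carbon gives a step beyond the scatter in this assay, for example a longer chain, an amine or a carboxylic acid, or a phenyl ring carrying a further group such as a methoxy. Also open is how much the number depends on the shared core, since all three compounds keep it unchanged and none of the steps shown speaks to a replacement of its nitrile.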